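The compounds below may be only part of what the source reports. "The series", "measured", "known", "first", "only" and "open" are said of these compounds alone.

Measured compounds in an ADME assay on a cell-free system (plasma, Homo sapiens) for protein binding, read by LC-MS, using equilibrium dialysis, with a stated time of 4 h, tested at 100 ug/mL:
compound 1 `O=c1cc(C(F)(F)F)[nH]c2cc(C(F)(F)F)cc(Nc3ccc(C(F)(F)F)cn3)c12` gives 99.7%
compound 2 `O=c1cc(C(F)(F)F)[nH]c2cc(C(F)(F)F)cc(Nc3ccc(F)cn3)c12` gives 99.8%

Compound 2 has the lowest unbound fraction of the two, and its nearest neighbour is compound 1, separated by a 1.5-fold lower unbound fraction from compound 1 to compound 2 (0.18 log units; within the scatter). Compound 3 `O=c1cc(C(F)(F)F)[nH]c2cc(C(F)(F)F)cc(N[C@H]3CC[C@H](C(F)(F)F)CC3)c12` has not been measured. It differs from compound 2 by 4-(trifluoromethyl)cyclohexyl in place of 5-fluoropyridin-2-yl on a nitrogen on an aromatic ring. For the measured compounds named here, the only measured step exchanges one substituent on an aromatic ring and does not resemble this change; it was within the scatter, and nothing measured here points to a step beyond the scatter. Compound 3 is therefore expected to give 99.8% in this assay, between 99.4% and 99.95%, an expected step of no change at the digits printed from compound 2 to compound 3 (within the scatter).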

Compound 3, plasma protein binding: 99.9%
The estimate for compound 3 lay 2.0-fold (0.30 log units) (unbound fraction) above the measured number; the measured number falls inside the stated range.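

At this place, on a nitrogen on an aromatic ring, 4-(trifluoromethyl)cyclohexyl in place of 5-fluoropyridin-2-yl gives in this assay a 2.0-fold lower unbound fraction from compound 2 to compound 3 (0.30 log units; within the scatter), so exchanging an aromatic ring for a non-aromatic one of carbon only stays within the scatter. Set against 5-(trifluoromethyl)pyridin-2-yl, the same cyclohexyl gives a 3.0-fold lower unbound fraction from compound 1 to compound 3 (0.48 log units; beyond the scatter), the first step in this series beyond the scatter, though a modest one. No available evidence bears on the origin of either step.

The compounds shown leave open whether an amine or a carboxylic acid in place of the trifluoromethyl on the cyclohexyl ring would shift the read-out in this assay further.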